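The source may hold more compounds than are shown below. What is called first, only, known or untested is meant among the compounds shown, and "the series" means these compounds.

Working notes on the hydroxamic acid series.

Compound 1 `O=C(CCCCCCc1nc2ccc(-c3cncnc3)cc2[nH]1)NO` carries a pyrimidin-5-yl on the shared core; in a functional assay on SK-OV-3 cells (Homo sapiens) for cytotoxicity (on this read-out lower numbers stand for stronger inhibition and higher numbers for weaker inhibition), compound 1 gives 2600 nM. Compound 2 `COc1ccc2nc(CCCCCCC(=O)NO)[nH]c2c1` has methoxy in that place and in this assay compound 2 gives 11000 nM. For the measured compounds named here, the one measured step, a 4.2-fold higher number from compound 1 to compound 2 (0.63 log units; beyond the scatter), is the whole of the data on substitution at this aromatic carbon. Going by the values given here, compound 2 therefore stands at the higher of the two numbers so far, with compound 1 the only neighbour.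

Compound 3 `CN(C)c1ccc2nc(CCCCCCC(=O)NO)[nH]c2c1` differs from compound 2 in one place: dimethylamino in place of methoxy on an aromatic carbon. Among the compounds with values here, no measured step covers a dimethylamino, and the only step on hand, methoxy in place of pyrimidin-5-yl, is modest and concerns a different pair of groups. Both groups leaving and entering bring no donor and one acceptor, so in this assay a step of no more than the usual scatter is expected, a 1.2-fold lower number from compound 2 to compound 3 (0.09 log units; within the scatter), with a slight lean toward a lower number. For compound 3 in this assay the estimate is 9000 nM, between 3500 nM and 25000 nM.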

Compound 3, half-maximal inhibitory concentration: 1200 nM
Compound 3: the middle estimate sits 7.5-fold (0.88 log units) above what was measured; measured number below the stated range.
By their numbers in this assay, from the lowest: compound 3; then compound 1; then compound 2.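

In this assay the aromatic carbon on the shared core responds strongly to a swap between two groups with no ring, giving a 9.2-fold lower number from compound 2 to compound 3 (0.96 log units; beyond the scatter) even though methoxy and dimethylamino carry the same count of hydrogen-bond donors and acceptors, so that count does not settle the number at this position. The change to dimethylamino also gives a 2.2-fold lower number from compound 1 to compound 3 (0.34 log units; beyond the scatter) and leaves compound 3 with the lowest number of the three, so the pyrimidin-5-yl ring is not needed for the lowest number seen here, although methoxy, also without a ring, goes against any reading that ring-free groups do better as a class. Nothing on hand gives a reason for either step.

The compounds shown leave open whether the lower number goes with the nitrogen on this carbon or with its two methyl groups, which a primary amine, a methylamino group or a pyrrolidine ring at the same carbon would help to separate. Also open, as far as these compounds go, is whether dimethylamino keeps its advantage over methoxy with a shorter or longer chain leading to the hydroxamic acid.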